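The source may report more compounds than this note shows. Statements on the series, on what has been measured and on what is new or still open speak of the compounds shown alone.

Measured compounds:
compound 1, `c1ccc(Cn2cncc2CNc2cccc(-c3ccccc3)c2)cc1`, > 750 nM (a limit)
compound 2, `COC(=O)c1ccc(NCc2cncn2Cc2ccccc2N)cc1-c1ccccc1`, 25000 nM
compound 3, `COC(=O)c1ccc(NCc2cncn2Cc2cccc(C#N)c2)cc1-c1ccccc1`, > 10000 nM (a limit)

In a toxicity assay on NIH3T3 cells (Mus musculus) for cytotoxicity, read by resazurin assay (on this read-out higher numbers stand for an effect only at larger amounts of compound and lower numbers for an effect already at smaller amounts), compound 3 gives only a limit, > 10000 nM. Compound 3 therefore stands at the limit of > 10000 nM in this assay, at which 1 of the 3 values shown sits. Compound 1 likewise returns only a limit, > 750 nM. Compound 1 stands at the limit of > 750 nM in this assay, at which 1 of the 3 values shown sits. Going by the values given here, compound 2 is the only member of the series with a numerical reading, 25000 nM, and it lies far from the region where cytotoxicity would be a concern for the series.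

Among the compounds with values here, the single step between measured compounds that differ in one place, a step that the limit leaves unreadable from compound 2 to compound 3, cannot be sized, as the value of compound 3 is a limit. Within the data shown here, no measured step touches the change now considered.

Compound 4, `COC(=O)c1ccc(NCc2cncn2Cc2cccc([N+](=O)[O-])c2)cc1-c1ccccc1`, differs from compound 3 by nitro in place of cyano on an aromatic carbon. Among the measured compounds shown here, nothing among the measured steps bears on a nitro in place of a cyano, so no step beyond the scatter is expected in this assay in either direction. Compound 4 is expected to remain weakly cytotoxic, at about 20000 nM, within 8000 nM to 50000 nM, and the resulting step that the limit leaves unreadable from compound 3 to compound 4 is estimated to be negligible, with a real chance that only a limit is reported again.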

Compound 4, half-maximal effective concentration: > 10000 nM
Compound 4: only a limit was reported (the forecaster's own chance of this, stated with the estimate: 55%); the middle value does not contradict the limit.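

In this assay compound 4 gives only a limit, > 10000 nM, so neither its step from compound 2 nor its step from compound 3 can be read, and compound 3 also sits at a limit: the limit of > 10000 nM in this assay, at which 2 of the 4 values shown sit. The compounds shown leave open whether nitro in place of cyano shifts the reading in this assay at all.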